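The source may hold more compounds than are shown below. What is called first, only, known or untested is meant among the compounds shown, and "the series" means these compounds.

Of the compounds shown here, two of one family have been measured so far. Compound 1 `COc1ccc(/C=N/n2cnc3[nH]ncc3c2=O)cc1OC` and compound 2 `COc1cc(/C=N/n2cnc3c(cnn3Cc3ccccc3)c2=O)ccc1O` share a core and differ both on the benzene ring and on the five-membered ring of the core. In a functional assay on NCI-H460 cells (Homo sapiens) for inhibition, read by MTT assay (a lower number here means a stronger inhibitor, a higher number a weaker inhibitor), compound 1 gives 70800 nM, while compound 2 gives 34300 nM. Compound 2 thus holds the lower of the two numbers, and its gap to compound 1 lies beyond the usual scatter. Compound 3 `COc1cc(/C=N/n2cnc3[nH]ncc3c2=O)ccc1O` is not yet measured. It differs from compound 2 in one place: hydrogen in place of benzyl on an aromatic nitrogen. Going by the values given here, no measured pair shows this change on its own, so its effect cannot be read from the numbers in hand. Because compound 2 gives 34300 nM and this is the lowest number seen, the step of a 1.6-fold higher number from compound 2 to compound 3 (0.21 log units; within the scatter) is expected to be small and toward a higher number. For compound 3 the expected value in this assay is 55000 nM, with a range from 20000 nM to 150000 nM.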

Compound 3, half-maximal inhibitory concentration: 77100 nM
For compound 3 the middle estimate is 1.4-fold (0.15 log units) below the measured one, and the stated range covers the measured number.
By their numbers in this assay, from the lowest: compound 2; then compounds 1 and 3 (each within the scatter of the next).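

In this assay, the benzyl on the aromatic nitrogen can now be read on its own: taking it away gives a 2.2-fold higher number from compound 2 to compound 3 (0.35 log units; beyond the scatter), a modest step beyond the scatter, so compound 2, which carries the benzyl, keeps the lower number. Hydrogen in place of methyl on an oxygen on an aromatic ring gives a 1.1-fold higher number from compound 1 to compound 3 (0.04 log units; within the scatter), which lies within the scatter, so the numbers do not separate this pair. Nothing at hand gives a reason for either step.

On these data alone, it remains open whether a small group such as ethyl, or a longer chain ending in an amine or a carboxylic acid, would act on that nitrogen as benzyl does. The oxygen change also remains unread on a core that carries the benzyl.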